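The source may report more compounds than this note shows. Statements on the series, on what has been measured and on what is new or still open speak of the compounds shown alone.

Measured compounds in an ADME assay on Vero cells (Chlorocebus sabaeus) for cytotoxicity, read by MTT assay, with a stated time of 48 h; on this read-out lower numbers stand for stronger inhibition and higher numbers for weaker inhibition:
Compound 1 `O=C(OC1CCC(CN2CCN(c3cc(=O)c4cc(C(F)(F)F)cc([N+](=O)[O-])c4s3)CC2)CC1)c1ccc(F)cc1`, a limit of the assay: > 64 ug/mL.
Compound 2 `O=C(OC1CCC(CN2CCN(c3cc(=O)c4cc(C(F)(F)F)cc([N+](=O)[O-])c4s3)CC2)CC1)c1cccs1`, a limit of the assay: > 64 ug/mL.
Compound 3 `O=c1cc(N2CCN(CC3CCC(OS(=O)(=O)c4ccc5ccccc5c4)CC3)CC2)sc2c([N+](=O)[O-])cc(C(F)(F)F)cc12`, a limit of the assay: > 64 ug/mL.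

Compound 2 stands only at a limit in this assay, as do the two other values shown, so no ordering among the three is readable. Compound 4 `O=C(NC1CCC(CN2CCN(c3cc(=O)c4cc(C(F)(F)F)cc([N+](=O)[O-])c4s3)CC2)CC1)c1ccccc1` differs from compound 2 by benzamido in place of ((thiophen-2-yl)carbonyl)oxy on a saturated ring carbon. Among the compounds with values here, the only measured step that bears on it, a step that the two limits leave unreadable from compound 1 to compound 2, is itself unreadable, and all three values sit at the limit of > 64 ug/mL in this assay, at which 3 of the 3 values shown sit. No step beyond the scatter is therefore expected from compound 2 to compound 4, a step that the limit leaves unreadable from compound 2 to compound 4, and compound 4 is expected to remain at the limit, estimated at 90 ug/mL with a range of 40 ug/mL to 200 ug/mL.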

Compound 4, half-maximal inhibitory concentration: 44.3 ug/mL
For compound 4 the middle estimate is 2.0-fold (0.31 log units) above the measured one; the measured number falls inside the stated range.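

In this assay, within the data shown here, compound 4 gives 44.3 ug/mL as a number rather than a limit, the first such reading at this saturated ring carbon. The steps of an at least 1.4-fold lower number from compound 2 to compound 4 (0.15 log units; that floor lies within the scatter) and an at least 1.4-fold lower number from compound 1 to compound 4 (0.15 log units; that floor lies within the scatter) come with benzamido in place of the two carbonyl-linked oxy groups, yet neither is shown to lie beyond the scatter. The other values give no order among themselves: the limit of > 64 ug/mL in this assay, at which 3 of the 4 values shown sit.

Open, on these data alone, is whether the change follows the amide hydrogen or the six-membered aromatic ring. Also open, as far as these compounds go, is the reading in this assay for an amine or a carboxylic acid on this ring carbon.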